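A few compounds are considered here, and "the series" means these few. Any claim that something is new, unique, unknown or untested is made for them only; others in the source may bear on it.

In an ADME assay on HepG2 2.2.15 cells (Homo sapiens) for cytotoxicity, read by MTT assay, with a stated time of 72 h (on this read-out lower numbers stand for higher toxicity in this test and higher numbers for lower toxicity in this test), compound 3 `O=C1OCCc2c(/C=N\O)cccc21` gives > 4000000 nM, and this figure is a limit of the assay rather than a number. The two companions in the set stand the same way. Compound 1 `CC(=O)OCc1cccc2c1CCOC2=O` gives > 2430000 nM in this assay, again a limit. Compound 2 `NC(=O)c1cccc2c1CCOC2=O` gives > 3290000 nM in this assay, also a limit. With every value a limit, the measured steps are a step that the two limits leave unreadable from compound 1 to compound 2, a step that the two limits leave unreadable from compound 1 to compound 3 and a step that the two limits leave unreadable from compound 2 to compound 3, none of them readable in size; the record behind them is the limit of > 2430000 nM in this assay, at which 1 of the 3 values shown sits, the limit of > 3290000 nM in this assay, at which 1 of the 3 values shown sits, and (the limit of > 4000000 nM in this assay, at which 1 of the 3 values shown sits).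

Compound 4 `O=C1OCCc2c1cccc2C1OCCO1` differs from compound 3 by a group of 5 heavy atoms (3 carbon, 2 oxygen; one five-membered non-aromatic ring with 2 hetero atoms) in place of a group of 3 heavy atoms (1 carbon, 1 nitrogen, 1 oxygen; no ring), on an aromatic carbon. Going by the values given here, no measured step carries a readable size that bears on this change, so the only guide is that compound 3 and its two companions all sit at a limit in this assay. The expected step is an at least 1.3-fold lower number from compound 3 to compound 4 (0.12 log units; that floor lies within the scatter), which is estimated to stay within the scatter. Compound 4 is therefore expected to give about 3000000 nM in this assay, with a range from 500000 nM to 6000000 nM, and most likely only a limit will be reported.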

Compound 4, half-maximal cytotoxic concentration: > 2580000 nM
Compound 4: a limit, no number (the forecaster's own chance of this, stated with the estimate: 80%); the middle value lies beyond the limit too.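

Going by these compounds alone, compound 4, like compound 1, compound 2 and compound 3, stands only as a limit in this assay, so no step between compound 4 and the other three can be read. The compounds shown leave open at what concentration any of the four becomes cytotoxic.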